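From 1H-pyrazol-1-yl to piperidin-1-yl on the shared core

This account rests on a few compounds, and the source may have more. Where it says the series, first, only, none or still open, it means among the compounds named here.

The three compounds measured so far in a functional assay on Huh-7 cells (Homo sapiens) for cytotoxicity, read by MTT assay, with a stated time of 3 days (a lower number here means that less compound is tolerated, a higher number that more compound is tolerated), read as follows
- Compound 1 `OC[C@H]1O[C@@H](n2cnc3c(COc4ccccn4)ncnc32)[C@H](O)[C@@H]1O` gives > 250000 nM (a limit)
- Compound 2 `O=C1CCCN1Cc1ncnc2c1ncn2[C@@H]1O[C@H](CO)[C@@H](O)[C@H]1O` gives 45000 nM
- Compound 3 `OC[C@H]1O[C@@H](n2cnc3c(Cn4cccn4)ncnc32)[C@H](O)[C@@H]1O` gives > 250000 nM (a limit)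

Compound 3 yields no number in this assay and stands at the limit of > 250000 nM in this assay, at which 2 of the 3 values shown sit, together with compound 1. Compound 4 `OC[C@H]1O[C@@H](n2cnc3c(CN4CCCCC4)ncnc32)[C@H](O)[C@@H]1O` departs from compound 3 by one change (piperidin-1-yl in place of 1H-pyrazol-1-yl on a saturated chain carbon bound to an aromatic carbon), piperidin-1-yl in place of 1H-pyrazol-1-yl on a saturated chain carbon bound to an aromatic carbon.

For the measured compounds named here, no measured step makes this exact swap. The nearest evidence lies in an at least 5.5-fold higher number from compound 2 to compound 3 (0.74 log units; beyond the scatter) and in an at least 5.5-fold lower number from compound 1 to compound 2 (0.74 log units; beyond the scatter) and both steps at this carbon lie beyond the scatter. Only compound 2 gives a number (45000 nM) and, of the three, it alone carries a non-aromatic ring, as compound 4 does. On that single value the expected step is an at least 4.1-fold lower number from compound 3 to compound 4 (0.61 log units; beyond the scatter) toward a lower number, though compound 4 may also stay at the limit. Compound 4 is expected at 60000 nM (estimated range 15000 nM to 250000 nM).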

Compound 4, half-maximal cytotoxic concentration: 87000 nM
Compound 4: middle estimate off by 1.5-fold (0.16 log units), on the low side, within the range that was stated.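

In this assay, compound 2 and compound 4, the two compounds with a non-aromatic ring on this saturated chain carbon, give numbers that do not separate: a 1.9-fold higher number from compound 2 to compound 4 (0.29 log units; within the scatter). The piperidin-1-yl group gives a lower number than either aromatic group, with an at least 2.8-fold lower number from compound 3 to compound 4 (0.45 log units; beyond the scatter) and an at least 2.8-fold lower number from compound 1 to compound 4 (0.45 log units; beyond the scatter), so across these four compounds the two non-aromatic rings stand apart from 1H-pyrazol-1-yl and (pyridin-2-yl)oxy. Compound 1 and compound 3 still give no number, each resting at a limit: the limit of > 250000 nM in this assay, at which 2 of the 4 values shown sit.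

As far as these compounds go, how far past that limit these two compounds lie remains open, so the full size of the split between the aromatic and non-aromatic groups cannot be given. From the compounds shown here alone, it is also open whether a morpholin-4-yl ring or an open-chain diethylamino group on this carbon would fall with compound 2 and compound 4.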